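One Added Methyl on an Amide Nitrogen

A few compounds are considered here, and "the series" means these few. Any claim that something is new, unique, unknown or untested is made for them only; others in the source may bear on it.

In a functional assay on PC-3 cells (Homo sapiens) for cytotoxicity, read by MTT assay, with a stated time of 72 h (on this read-out higher numbers stand for weaker inhibition and lower numbers for stronger inhibition), compound 1 `COc1ccc(OC)c(C(=O)/C=C/c2ccc(C(=O)OCC=C(C)C)cc2)c1` gives > 50000 nM, a limit and not a number. Among the compounds with values here, compound 2 `CNC(=O)c1ccc(/C=C/C(=O)c2cc(OC)ccc2OC)cc1`, at 2130 nM, holds the only true number so far. Within the data shown here, the sole measured step, an at least 23-fold lower number from compound 1 to compound 2 (1.37 log units; beyond the scatter), is large, but it put methylamino in place of (3-methylbut-2-en-1-yl)oxy and rests on (the limit of > 50000 nM in this assay, at which 1 of the 2 values shown sits). Compound 3 `COc1ccc(OC)c(C(=O)/C=C/c2ccc(C(=O)N(C)C)cc2)c1` differs from compound 2 by methyl in place of hydrogen on an amide-type nitrogen, with methyl in place of hydrogen on an amide-type nitrogen, so only a much smaller move is expected. The expected step in this assay is a 1.6-fold higher number from compound 2 to compound 3 (0.22 log units; within the scatter), modestly toward weaker inhibition. Compound 3 is estimated at 3500 nM, with an expected range of 900 nM to 15000 nM.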

Compound 3, half-maximal inhibitory concentration: 4580 nM
For compound 3 the middle estimate is 1.3-fold (0.12 log units) below the measured one; the range from low to high includes it.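

In this assay, methyl in place of the amide hydrogen gives a 2.2-fold higher number from compound 2 to compound 3 (0.33 log units; beyond the scatter), so a second methyl on this nitrogen shifts the result only modestly toward weaker inhibition. The large drop seen with methylamino also holds for dimethylamino in place of (3-methylbut-2-en-1-yl)oxy, with an at least 10-fold lower number from compound 1 to compound 3 (1.03 log units; beyond the scatter). That step gives only a minimum size, as compound 1 is a limit and not a number: the limit of > 50000 nM in this assay, at which 1 of the 3 values shown sits.

The compounds shown leave open how a plain unsubstituted amide, a longer chain on this nitrogen or a carboxylic acid on the carbonyl carbon would compare.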